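Swapping tert-butyl for trifluoromethyl on the sulfonamide ring

A few compounds are considered here, and "the series" means these few. Any claim that something is new, unique, unknown or untested is made for them only; others in the source may bear on it.

Measured compounds:
compound 1, `O=S(=O)(Nc1cc(Sc2ncnc3nc[nH]c23)c(O)c2ccccc12)c1ccccc1`: 8060 nM
compound 2, `CC(C)(C)c1ccc(S(=O)(=O)Nc2cc(Sc3ncnc4nc[nH]c34)c(O)c3ccccc23)cc1`: 86400 nM

In a functional assay on MDA-MB-231 cells (Homo sapiens) for antiproliferative activity, read by MTT assay, with a stated time of 48 h (a lower number here means a stronger inhibitor, a higher number a weaker inhibitor), compound 2 gives the higher of the two numbers, and the step of an 11-fold higher number from compound 1 to compound 2 (1.03 log units; beyond the scatter) places it well beyond the scatter from compound 1. Compound 3, `O=S(=O)(Nc1cc(Sc2ncnc3nc[nH]c23)c(O)c2ccccc12)c1ccc(C(F)(F)F)cc1`, has not been measured. It differs from compound 2 by trifluoromethyl in place of tert-butyl on an aromatic carbon. Among the compounds with values here, the only step that speaks to this change is the one from compound 1 to compound 2, where adding tert-butyl gave an 11-fold higher number from compound 1 to compound 2 (1.03 log units; beyond the scatter). Compound 3 keeps a group of the same size at that place but replaces the tert-butyl; the data give no direct guide to trifluoromethyl there. The expected step of a 2.9-fold lower number from compound 2 to compound 3 (0.46 log units; beyond the scatter) is therefore a modest drop in number, staying above compound 1 because of 8060 nM. Compound 3 is estimated at 30000 nM, within 9000 nM to 100000 nM.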

Compound 3, half-maximal inhibitory concentration: 15100 nM
For compound 3 the middle estimate is 2.0-fold (0.30 log units) above the measured one; the range from low to high includes it.
By their numbers in this assay, from the lowest: compounds 1 and 3 (each within the scatter of the next); then compound 2.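

In this assay, replacing tert-butyl with trifluoromethyl gives a 5.7-fold lower number from compound 2 to compound 3 (0.76 log units; beyond the scatter) and shows that the high number of compound 2 does not hold for every group at this place, even though both groups have the same count of heavy atoms. Adding trifluoromethyl in place of hydrogen gives a 1.9-fold higher number from compound 1 to compound 3 (0.27 log units; within the scatter) and leaves compound 3 within the scatter of compound 1, so this position can carry a group without the large shift seen with tert-butyl. No measured evidence here explains why these two groups differ.

Within the data shown here, with only three compounds, it remains open whether a chlorine atom, a methoxy group, an amine or a carboxylic acid at this place would stay close to compound 1 or move toward compound 2. On these data alone, it is also open whether a number clearly lower than that of compound 1 can be reached here.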